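Thiophene for fluorophenyl on a benzimidazole desaturase inhibitor

The source may report more compounds than this note shows. Statements on the series, on what has been measured and on what is new or still open speak of the compounds shown alone.

Compound 2 `CS(=O)(=O)c1ccc2nc(-c3ccc(-c4cccc(F)c4)cc3)[nH]c2c1` and compound 1 `CS(=O)(=O)c1ccc2nc(-c3ccc(-c4ccccc4)cc3)[nH]c2c1` share one core and differ only at the outer aromatic ring. In an assay on isolated protein for inhibition of acyl-CoA desaturase 1 (Rattus norvegicus) (a higher number here means a weaker inhibitor, a lower number a stronger inhibitor), compound 1 gives 20 nM, and compound 2 gives 21 nM. Within the data shown here, the change a 1.1-fold higher number from compound 1 to compound 2 (0.02 log units; within the scatter) is within the scatter, so the two values are indistinguishable, and compound 2 stands level with its only neighbour.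

Compound 3 `CS(=O)(=O)c1ccc2nc(-c3ccc(-c4ccsc4)cc3)[nH]c2c1` takes the next step from compound 2: thiophen-3-yl in place of 3-fluorophenyl on an aromatic carbon. Among the measured compounds shown here, the single measured step, from compound 1 to compound 2, bears on this only loosely, since it shows that a fluoro on the outer ring leaves this assay unchanged; nothing measured here speaks to swapping the whole six-membered ring for a five-membered one. Given that a change at this position produced a 1.1-fold higher number from compound 1 to compound 2 (0.02 log units; within the scatter), compound 3 is expected to stay near compound 2, with a step of a 1.2-fold higher number from compound 2 to compound 3 (0.08 log units; within the scatter) that may be nothing beyond the scatter. Compound 3 is therefore estimated at 25 nM in this assay, within a range of 10 nM to 65 nM.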

Compound 3, half-maximal inhibitory concentration: 104 nM
Estimate against measurement, compound 3: 4.2-fold (0.62 log units) below, outside the stated range (above it).
By their numbers in this assay, from the lowest: compounds 1 and 2 (each within the scatter of the next); then compound 3.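

Thiophen-3-yl in place of 3-fluorophenyl gives a 5.0-fold higher number from compound 2 to compound 3 (0.69 log units; beyond the scatter) in this assay, and thiophen-3-yl in place of phenyl gives a 5.2-fold higher number from compound 1 to compound 3 (0.72 log units; beyond the scatter) on the same aromatic carbon, so a position that showed no response to a fluoro does respond when the whole outer ring is exchanged. Compound 1 and compound 2 stand level within the scatter, so the modest weakening appears from either six-membered ring and does not depend on which of the two serves as the reference. Ring size and the hetero atom change together in this single swap, so the compounds cannot separate the two, and no supporting measurement bears on why the number rises.

Going by these compounds, what stays open is whether a pyridin-3-yl ring, which keeps six members and carries a ring nitrogen, would follow phenyl or thiophen-3-yl at this carbon. Equally open, on these data alone, is whether a furan-3-yl ring, or an amine or a carboxylic acid on the outer ring, would move the number in either direction.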